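This account rests on a few compounds, and the source may have more. Where it says the series, first, only, none or still open, it means among the compounds named here.

Working notes on the series, read in an ADME assay on microsomes from liver (Homo sapiens) for metabolic stability; on this read-out higher numbers stand for fast clearance and lower numbers for slow clearance:

- compound 1 `C[C@H](NC(=O)Cn1nnc2ccccc2c1=O)c1ccc(Cl)cc1`: < 9.9 mL/min/kg (a limit of the assay, not a number)
- compound 2 `Cc1ccc([C@H](C)NC(=O)Cn2nnc3ccccc3c2=O)cc1`: < 9.9 mL/min/kg (a limit of the assay, not a number)
- compound 3 `COc1cc(C)ccc1[C@H](C)NC(=O)Cn1nnc2ccccc2c1=O`: 30 mL/min/kg
- compound 4 `CC[C@H](NC(=O)Cn1nnc2ccccc2c1=O)c1ccc(C)cc1`: not yet measured

Compound 2 has no number of its own and stands only at the limit of < 9.9 mL/min/kg in this assay, at which 2 of the 3 values shown sit. Compound 4 differs from compound 2 by one change: methyl in place of hydrogen on a saturated chain carbon, two bonds along the chain from an amide-type nitrogen and an aromatic carbon. In words, this is methyl to ethyl, with methyl in place of hydrogen on a saturated chain carbon, two bonds along the chain from an amide-type nitrogen and an aromatic carbon.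

Among the compounds with values here, no measured step touches that chain carbon, so the guidance is indirect. Both measured steps are changes on an aromatic carbon. One is a step that the two limits leave unreadable from compound 1 to compound 2, which gives no size to work with. The other is an at least 3.0-fold higher number from compound 2 to compound 3 (0.48 log units; beyond the scatter), and it shows that one added group can take compound 3 to a measured 30 mL/min/kg. On that single guide, a rise is expected rather than a fall, though a smaller one, and compound 4 may still report only a limit. The estimated step is an at least 1.3-fold higher number from compound 2 to compound 4 (0.11 log units; that floor lies within the scatter). For compound 4 the expected clearance is 13 mL/min/kg, with an estimated range from 7 mL/min/kg to 28 mL/min/kg.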

Compound 4, clearance: 31 mL/min/kg
Compound 4: the middle estimate sits 2.4-fold (0.38 log units) below what was measured; the whole stated range lies below it.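

In this assay, the saturated chain carbon two bonds along the chain from an amide-type nitrogen and an aromatic carbon now has a measured step of its own: methyl to ethyl gives an at least 3.1-fold higher number from compound 2 to compound 4 (0.49 log units; beyond the scatter). This position is therefore not silent on this read-out, since a change of a single methyl, with no ring and no hydrogen-bond donors or acceptors, is enough to give a measured clearance while the aromatic part of the molecule stays as it was. The true size of the step remains a floor because compound 2 has only a limit of the assay and no number: the limit of < 9.9 mL/min/kg in this assay, at which 2 of the 4 values shown sit.

Going by these compounds, how a longer chain such as propyl, or a cyclopropyl group, would read at this chain carbon remains open, so one step cannot yet show a trend with chain length. Also open, on these data alone, is whether the same change from methyl to ethyl gives a step of similar size when the aromatic ring carries the chloro group of compound 1 or the methoxy group of compound 3.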